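Aniline variation on a shared quinazoline-type core in cytotoxicity

This account rests on a few compounds, and the source may have more. Where it says the series, first, only, none or still open, it means among the compounds named here.

Measured compounds:
- compound 1, `COc1ccc(Nc2nc(-c3cccc(F)c3)nc3ccc(F)cc23)cc1`, 32300 nM
- compound 2, `Oc1cccc(Nc2nc(-c3cccc(F)c3)nc3ccc(F)cc23)c1`, 33300 nM

Compound 1 and compound 2 share the core of compound 1 and differ only in the aryl group on the ring nitrogen. In a functional assay on U2OS cells (Homo sapiens) for cytotoxicity, read by MTT assay, with a stated time of 48 h (a higher number here means a weaker inhibitor, a lower number a stronger inhibitor), compound 1 gives 32300 nM and compound 2 gives 33300 nM; the step of a 1.0-fold higher number from compound 1 to compound 2 (0.01 log units; within the scatter) is within the scatter. Compound 2 thus stands highest of the two numbers, but not separably from compound 1.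

Compound 3, `Nc1ccccc1Nc1nc(-c2cccc(F)c2)nc2ccc(F)cc12`, carries the change (2-aminophenyl in place of 3-hydroxyphenyl on a nitrogen on an aromatic ring). Among the compounds with values here, no measured step covers this exchange. Within the data shown here, the only step in hand, from compound 1 to compound 2, swapped one aryl group for another on the same nitrogen and left the number unchanged within the scatter. On that basis alone, the exchange to a 2-aminophenyl group is expected to give no step beyond the scatter in this assay, in either direction; the expected step is a 1.0-fold lower number from compound 2 to compound 3 (0.00 log units; within the scatter). Compound 3 is therefore estimated at 33000 nM, with a range from 12000 nM to 90000 nM, the width reflecting that a single flat step is thin ground.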

Compound 3, half-maximal inhibitory concentration: 37900 nM
Estimate against measurement, compound 3: 1.1-fold (0.06 log units) below; measured number inside the range.
By their numbers in this assay, from the lowest: compounds 1, 2 and 3 (each within the scatter of the next).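

In this assay, putting 2-aminophenyl on the nitrogen gives a 1.1-fold higher number from compound 2 to compound 3 (0.06 log units; within the scatter) and a 1.2-fold higher number from compound 1 to compound 3 (0.07 log units; within the scatter), so neither exchange separates the compounds. This extends the flat picture at this nitrogen from the two oxygen-bearing aryl groups to one bearing a nitrogen substituent: 3-hydroxyphenyl and 2-aminophenyl match in heavy-atom and hydrogen-bond counts and differ in that one atom and its place on the ring, and the exchange leaves the number within the scatter. Nothing available accounts for this lack of separation among compounds 1, 2 and 3, so it stands as an observation without an explanation.

As far as these compounds go, all three groups are substituted phenyl rings, so it remains open whether any group on this nitrogen can separate from them, for instance a carboxylic acid on the ring or a longer chain in place of the ring. From the compounds shown here alone, it also remains open whether the same flatness would hold once another part of the shared core is changed.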